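The source may hold more compounds than are shown below. What is called first, only, known or untested is meant among the compounds shown, and "the series" means these compounds.

Of the compounds shown here, two of this small series have been measured in an assay on COS-7 cells for inhibition of patatin-like phospholipase domain-containing protein 2 (Mus musculus), tested at 200 uM; a higher number here means more inhibition at the concentration tested (going by the name of the read-out), a lower number less inhibition. Compound 1 `CCOC(=O)c1ccc(-c2ccc(OCC)cc2)o1` carries an ethoxy group on its outer six-membered ring, and in this assay compound 1 gives 93%. Compound 2 `CCOC(=O)c1cccc(-c2ccc(O)cc2)c1` is built on a different core and carries a hydroxy group on its outer ring. In this assay compound 2 gives 77%, the lower of the two numbers; the gap to compound 1 lies beyond the usual scatter of repeated measurements. Within the data shown here, because the two compounds differ in more than one place, the pair shows only that compound 1 reaches the higher inhibition, and nothing more can be drawn from it.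

Compound 3 `CCOC(=O)c1cccc(-c2ccc([N+](=O)[O-])cc2)c1` is the compound still to be measured. It differs from compound 2 in one place: nitro in place of hydroxy on an aromatic carbon. Among the measured compounds shown here, no measured step of this kind exists, so the expectation rests on the value of compound 2 alone. The step of a number 5 percentage points lower from compound 2 to compound 3 (within the scatter) is expected to stay within the scatter, with no clear direction. Compound 3 is therefore expected to give 72% in this assay, with a likely range from 45% to 95%.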

Compound 3, a percentage reported as inhibition, at one concentration (the size of the read-out at that concentration, not a potency): 63%
Compound 3: the middle estimate sits 9 percentage points above what was measured; the measured number falls inside the stated range.
By their numbers in this assay, from the lowest: compound 3; then compound 2; then compound 1.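

Placing nitro instead of hydroxy on the aromatic carbon para to a large group gives a number 14 percentage points lower from compound 2 to compound 3 (beyond the scatter) in this assay. Among these compounds, this is the first comparison in which only one place changes, so, unlike the gap between compound 1 and compound 2, it links a difference in inhibition to a single position and shows that the group there affects the read-out. The change swaps a group that has a hydrogen-bond donor for one that has none and also adds heavy atoms, but nothing measured here shows which of these differences, if either, matters for the lower number.

One step cannot show whether the trend depends on the hydrogen-bond donor, on the size of the group, or on something else, and an amine or a methoxy group at the same position would test this further. As far as these compounds go, it also remains open how the ethoxy group of compound 1 would behave on the core shared by compound 2 and compound 3, which would allow a one-place comparison with both.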